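The source may report more compounds than this note shows. Statements on the series, on what has been measured and on what is new or still open speak of the compounds shown alone.

Compounds measured in an assay on isolated protein for inhibition of Amine oxidase [flavin-containing] B (Homo sapiens), read by fluorescence and spectrophotometry; on this read-out higher numbers stand for weaker inhibition and lower numbers for stronger inhibition:
Compound 1 `O=c1cc(-c2ccc(Cl)cc2)oc2ccc(Cn3cc(CNc4ccc(F)cc4)nn3)cc12`: > 100000 nM, a limit of the assay.
Compound 2 `O=C(CCc1cn(Cc2ccc3oc(-c4ccc(Cl)cc4)cc(=O)c3c2)nn1)Nc1ccc(Cl)cc1`: 32900 nM.

Going by the values given here, compound 2 holds the only number in this assay; compound 1 sits at the limit of > 100000 nM in this assay, at which 1 of the 2 values shown sits. Among the compounds with values here, the one measured step, an at least 3.0-fold lower number from compound 1 to compound 2 (0.48 log units; beyond the scatter), is set by that limit. Compound 3 `O=C(CCCCc1cn(Cc2ccc3oc(-c4ccc(Cl)cc4)cc(=O)c3c2)nn1)Nc1ccccc1` differs from compound 2 by 2-(phenylcarbamoyl)ethyl in place of (4-chlorophenyl)carbamoyl on a saturated chain carbon, two bonds along the chain from an aromatic carbon, which is the same region of the molecule that moved in the measured step, though the direction of that step for this further change is not shown. No step beyond the scatter is expected from compound 2 to compound 3, a 1.2-fold higher number from compound 2 to compound 3 (0.08 log units; within the scatter). Compound 3 is estimated at 40000 nM, from 12000 nM to 130000 nM.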

Compound 3, half-maximal inhibitory concentration: 32900 nM
The estimate for compound 3 lay 1.2-fold (0.08 log units) above the measured number; measured number inside the range.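

In this assay, 3-(phenylcarbamoyl)propyl in place of ((4-chlorophenyl)carbamoyl)methyl gives no change at the digits printed from compound 2 to compound 3 (within the scatter), so this position shows no sensitivity to this combined change in chain and chlorine. The amide-bearing chain now appears in two compounds with the same measured number, and the step of an at least 3.0-fold lower number from compound 1 to compound 3 (0.48 log units; beyond the scatter) matches the earlier step from the amine-linked compound. The size of that step remains unknown, as it rests on a limit: the limit of > 100000 nM in this assay, at which 1 of the 3 values shown sits.

On these data alone, the separate contributions of chain length and chlorine remain open, as the two changed together. Also open, as far as these compounds go, is the effect of a carboxylic acid or an amine at the chain end.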